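A few compounds are considered here, and "the series" means these few. Any claim that something is new, unique, unknown or untested is made for them only; others in the source may bear on it.

From the compounds shown here alone, three measured compounds share a core, and a fourth built on the same core is still untested. In a functional assay on Jurkat cells (Homo sapiens) for cytotoxicity, read by luminescence and CellTiter-Glo, with a stated time of 3 days (on this read-out lower numbers stand for stronger inhibition and higher numbers for weaker inhibition), compound 3 `O=C(Nc1ccc(C(F)(F)F)cc1)c1cc(F)ccc1O` gives 580 nM. Compound 1 `O=C(Nc1ccc(C(F)(F)F)cc1)c1cc(Cl)ccc1O` differs from compound 3 by chloro in place of fluoro on an aromatic carbon, and in this assay compound 1 gives 710 nM, so the step is a 1.2-fold higher number from compound 3 to compound 1 (0.09 log units; within the scatter). Compound 2 `O=C(Nc1ccc(OC(F)(F)F)c(Cl)c1)c1cc(F)ccc1O` carries a different core; the difference between its core and that of compound 3 is not broken down here. In this assay compound 2 gives 700 nM. Compound 4 `O=C(Nc1ccc(OC(F)(F)F)c(Cl)c1)c1cc(Cl)ccc1O` differs from compound 2 by chloro in place of fluoro on an aromatic carbon, the same change as from compound 3 to compound 1. The step is expected to be a 1.0-fold higher number from compound 2 to compound 4 (0.01 log units; within the scatter), because a 1.2-fold higher number from compound 3 to compound 1 (0.09 log units; within the scatter) was small. For compound 4 the estimated value in this assay is 720 nM, expected between 360 nM and 1450 nM.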

Compound 4, half-maximal inhibitory concentration: 840 nM
Compound 4: the middle estimate sits 1.2-fold (0.07 log units) below what was measured; measured number inside the range.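

Putting chloro in place of fluoro on this aromatic carbon, para to a hydroxy group, gives in this assay a 1.2-fold higher number from compound 2 to compound 4 (0.08 log units; within the scatter). The change reads alike on the two cores: the same change on two cores in this assay, a 1.2-fold higher number (0.09 log units; within the scatter) from compound 3 to compound 1 and a 1.2-fold higher number (0.08 log units; within the scatter) from compound 2 to compound 4, 1.0-fold (0.01 log units) apart, within the scatter of two such steps. This shows that a small step on one core was matched by a small step on the other, but with both steps within the scatter it does not show that chloro and fluoro differ here, and two cores say nothing about how the change would read on a third.

All the compounds shown carry a halogen at this place, so an amine or a carboxylic acid there remains open. From the compounds shown here alone, the hydroxy group is also present throughout, so the result of replacing it with a methoxy group remains open too.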